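Swapping phenyl for 2-fluoropyridin-4-yl on the thiazole core

The source may hold more compounds than are shown below. What is called first, only, known or untested is meant among the compounds shown, and "the series" means these compounds.

The study measures displacement of a labelled ligand in an in vitro assay on HEK385-7 cells for displacement of a labelled ligand from prostaglandin D2 receptor 2 (Homo sapiens); a higher number here means a weaker inhibitor, a lower number a stronger inhibitor. Compound 1 `O=C(O)Cc1sc(C(c2ccccc2)c2ccccn2)nc1-c1ccc(Cl)cc1` gives 810 nM in this assay. Within the data shown here, compound 2 `COc1ccc(C(c2ccccn2)c2nc(-c3ccc(Cl)cc3)c(CC(=O)O)s2)cc1` gives 61 nM, and the single-point step a 13-fold lower number from compound 1 to compound 2 (1.12 log units; beyond the scatter) is the only measured step in the set. Compound 3 `O=C(O)Cc1sc(C(c2ccc(F)cc2)c2ccc(F)cc2)nc1-c1ccccc1` gives 16 nM, the lowest of the three numbers; its nearest neighbour is compound 2, and compound 1 lies furthest from it.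

Compound 4 `O=C(O)Cc1sc(C(c2ccc(F)cc2)c2ccc(F)cc2)nc1-c1ccnc(F)c1` differs from compound 3 in one place: 2-fluoropyridin-4-yl in place of phenyl on an aromatic carbon. Among the measured compounds shown here, no measured step bears on this change. For the measured compounds named here, the step from compound 1 to compound 2 concerns a methoxy in place of hydrogen on a different aromatic carbon, and nothing among the measured compounds varies the ring next to the ring nitrogen of the five-membered core. Going by the values given here, with no comparable precedent, the expectation for compound 4 rests on compound 3 alone, and the step of a 1.6-fold higher number from compound 3 to compound 4 (0.19 log units; within the scatter) is expected to be small, with a wide margin of uncertainty in either direction. Compound 4 is therefore estimated at 25 nM, within a range of 8 nM to 80 nM.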

Compound 4, half-maximal inhibitory concentration: 0.48 nM
The estimate for compound 4 lay 52-fold (1.72 log units) above the measured number, and the stated range ends above it.
By their numbers in this assay, from the lowest: compound 4; then compound 3; then compound 2; then compound 1.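

In this assay, the aromatic carbon next to the ring nitrogen proves highly sensitive to the group it carries: replacing phenyl with 2-fluoropyridin-4-yl gives a 33-fold lower number from compound 3 to compound 4 (1.52 log units; beyond the scatter), a large step at a position that no earlier comparison had varied. It also shows that the bis(4-fluorophenyl) compounds still had room to move well below the number of compound 3, with compound 4 at 0.48 nM giving the lowest number of the four. Nothing available here accounts for the size of this step.

The change brings in a ring nitrogen and a fluorine together, so these compounds cannot show how much of the step belongs to either one; an unsubstituted pyridin-4-yl ring and a phenyl ring bearing only fluorine would be the direct comparisons. Also open, as far as these compounds go, is whether a chlorine or an amine in place of that fluorine would hold the number, and whether the same swap would produce a similar step in compound 1 or compound 2, which carry a different group at the other end of the core.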